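The source may hold more compounds than are shown below. What is called first, only, known or untested is meant among the compounds shown, and "the series" means these compounds.

Going by the values given here, in a functional assay on the whole organism with Mus musculus as the target (a lower number here means that less compound is needed, a higher number that more compound is needed for the effect), compound 1 `NC(=O)Cn1c(-c2ccc(Br)cc2)nc2cccnc21` gives 17.8 mg/kg and compound 2 `CN(C)C(=O)Cn1c(-c2ccc(Br)cc2)nc2cccnc21` gives 7 mg/kg as the lowest of the two numbers so far. Among the compounds with values here, the only measured step is a 2.5-fold lower number from compound 1 to compound 2 (0.41 log units; beyond the scatter) on a carbonyl carbon, with dimethylamino in place of amino. Compound 3 `CN(C)C(=O)Cn1c(-c2ccsc2)nc2cccnc21` keeps the dimethylamino group and differs from compound 2 at another place on the shared core, with thiophen-3-yl in place of 4-bromophenyl on an aromatic carbon as the whole change. Within the data shown here, no measured step covers this place, so the one step on the carbonyl carbon serves only as a rough gauge of size. A modest step is expected, tentatively towards a higher number, and nothing measured fixes that direction. The estimated step is a 1.4-fold higher number from compound 2 to compound 3 (0.15 log units; within the scatter) in this assay and it carries wide uncertainty. Compound 3 is estimated at 10 mg/kg with an expected range from 3 mg/kg to 30 mg/kg in this read-out.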

Compound 3, dose for half-maximal effect: 38 mg/kg
Compound 3: middle estimate off by 3.8-fold (0.58 log units), on the low side; measured number above the stated range.
By their numbers in this assay, from the lowest: compound 2; then compound 1; then compound 3.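

In this assay, the place on an aromatic carbon of the five-membered ring, between two ring nitrogen atoms, also moves the number, with thiophen-3-yl in place of 4-bromophenyl giving a 5.4-fold higher number from compound 2 to compound 3 (0.73 log units; beyond the scatter) while the dimethylamino amide stays unchanged. The series now has two places with a step beyond the scatter, the other being the amide, with a 2.5-fold lower number from compound 1 to compound 2 (0.41 log units; beyond the scatter). This single exchange alters the ring size, the ring hetero atom and the bromine together, so the step cannot be assigned to any one of them, and no measurement at hand explains it.

The compounds shown leave open whether the bromine or the six-membered ring carries the difference, which a plain phenyl or 4-chlorophenyl group at this place would separate. Also open, going by these compounds, is whether thiophen-3-yl gives a step of similar direction on the primary amide of compound 1.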